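Methoxy in place of hydrogen: cytotoxicity notes on the series

The source may report more compounds than this note shows. Statements on the series, on what has been measured and on what is new or still open speak of the compounds shown alone.

Measured values in an ADME assay on HEp-2 cells (Homo sapiens) for cytotoxicity, read by MTT assay, with a stated time of 3 days; on this read-out lower numbers stand for higher toxicity in this test and higher numbers for lower toxicity in this test:
compound 1, `CC[C@H](CCn1cncn1)c1ccccc1`, gives 97.7 ug/mL
compound 2, `CC[C@@H](CCn1cncn1)c1ccccc1`, gives 89.9 ug/mL
compound 3, `CC[C@@H](CCn1cncn1)c1ccc(C)cc1`, gives 69.9 ug/mL

Compound 1 carries the highest of the three numbers, yet both others lie within the scatter of it: a 1.1-fold lower number from compound 1 to compound 2 (0.04 log units; within the scatter), and compound 3 sits only slightly further off. The configuration step rests on the fact that compounds 1 and 2 differ only in the configuration as drawn and does not bear on the next change, since compound 4, `CC[C@H](CCn1cncn1)c1ccc(OC)cc1`, keeps the configuration of compound 1. The change is methoxy in place of hydrogen on an aromatic carbon. Among the compounds with values here, the only comparable step is the aromatic substitution a 1.3-fold lower number from compound 2 to compound 3 (0.11 log units; within the scatter), within the scatter. On that basis no step beyond the scatter is expected: compound 4 is estimated at 80 ug/mL, range 40 ug/mL to 160 ug/mL, meaning a 1.2-fold lower number from compound 1 to compound 4 (0.09 log units; within the scatter).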

Compound 4, half-maximal cytotoxic concentration: 153 ug/mL
Compound 4: middle estimate off by 1.9-fold (0.28 log units), on the low side; the range from low to high includes it.
By their numbers in this assay, from the lowest: compounds 3, 2, 1 and 4 (each within the scatter of the next, the first and the last beyond it).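

In this assay methoxy in place of hydrogen on an aromatic carbon, para to a large group, gives a 1.6-fold higher number from compound 1 to compound 4 (0.19 log units; within the scatter), so this position takes an oxygen-bearing group without a step beyond the scatter. The methyl step, a 1.3-fold lower number from compound 2 to compound 3 (0.11 log units; within the scatter), starts from the other drawn configuration, so the two steps are not set against each other. Nothing measured in the series gives a cause for the methoxy step.

Open: whether an amine or a carboxylic acid at this position would stay within the scatter. Methoxy on the configuration of compound 2 also remains open.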